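The source may hold more compounds than are shown below. What is called first, only, known or untested is meant among the compounds shown, and "the series" means these compounds.

Three compounds of the series have numbers in a functional assay on HeLa cells (Homo sapiens) for antiproliferative activity, read by CCK-8 assay, with a stated time of 72 h, tested at 8 uM; a lower number here means a weaker effect, a higher number a stronger effect of the compound at the concentration tested. Compound 1 `Nc1ccccc1NC(=O)c1ccc(CSC(=S)N2CCc3cc(Cl)ccc32)cc1` gives 65.1%. Compound 2 `N#Cc1ccc(N2CCN(C(=S)SCc3ccc(C(=O)Nc4ccccc4N)cc3)CC2)cc1` gives 70.6%. Compound 3 `COC(=O)c1ccc2c(c1)CCN2C(=S)SCc1ccc(C(=O)Nc2ccccc2N)cc1` gives 60.1%. Compound 2 holds the highest of the three numbers, though its gap to compound 1 is within the scatter and only its gap to compound 3 lies beyond it. For the measured compounds named here, the one step between compounds that differ in a single place is a number 5 percentage points lower from compound 1 to compound 3 (within the scatter), a change at an aromatic carbon rather than at the amine nitrogen.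

Compound 4 `Nc1ccccc1NC(=O)c1ccc(CSC(=S)N2CCN(Cc3ccccc3)CC2)cc1` has not been measured. It differs from compound 2 in one place: benzyl in place of 4-cyanophenyl on an amine nitrogen in a ring. Going by the values given here, no measured step exchanges the group on this ring nitrogen, so the measured step gives no direct guide; it shows only that a change elsewhere on the core left the number within the scatter, and all three measured numbers sit in a narrow band. The step of a number 8.6 percentage points lower from compound 2 to compound 4 (within the scatter) is therefore expected to be small. A slight downward lean is assumed since compound 2 holds the highest measured number at 70.6%. Compound 4 is expected to give 62% in this assay, within 45% to 78%.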

Compound 4, a percentage reported as inhibition, at one concentration (the size of the read-out at that concentration, not a potency): 31.3%
Beside the measured number, compound 4's estimate is 30.7 percentage points above it; the whole stated range lies above it.
By their numbers in this assay, from the lowest: compound 4; then compounds 3, 1 and 2 (each within the scatter of the next, the first and the last beyond it).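

In this assay, for the compounds shown here, the group on the amine nitrogen of the six-membered ring with 2 nitrogen is the first place where a single exchange moves the number beyond the scatter, with benzyl in place of 4-cyanophenyl giving a number 39.3 percentage points lower from compound 2 to compound 4 (beyond the scatter). This position is therefore not tolerant of every aromatic group, even though both the leaving and the entering group carry one six-membered aromatic ring of carbon only. The exchange removes the nitrile, with its one hydrogen-bond acceptor, and also puts a carbon link between the ring and the nitrogen, and no measurement shown here gives a reason for the lower number.

The compounds shown leave open which of these two differences goes with the drop, since the single step changes both at once; a plain phenyl or a 4-cyanobenzyl on the same nitrogen would separate them. Also open, from the compounds shown here alone, is whether a non-aromatic group on this nitrogen, such as a simple alkyl chain or an acyl group, would sit nearer compound 2 or compound 4.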